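A few compounds are considered here, and "the series" means these few. Any claim that something is new, unique, unknown or untested is made for them only; others in the source may bear on it.

Compound 2, `Nc1ccc2cccc(OCC3CCCC3)c2n1`, holds the lowest number of the three compounds measured in an assay on cells with melanin-concentrating hormone receptor 1 (Homo sapiens) as the target, read by radioligand binding; on this read-out lower numbers stand for stronger inhibition and higher numbers for weaker inhibition. Compound 2 gives 53 nM. Within the data shown here, compound 1, `Nc1ccc2cccc(OC3CCCCC3)c2n1`, gives 361 nM, and compound 3, `Nc1ccc2cccc(OC3CCCCCC3)c2n1`, gives 137 nM; the values of compound 2 and compound 3 show compound 3 at a higher number, but no single-change step joins these two compounds. Among the measured compounds shown here, the one measured step is a 6.8-fold lower number from compound 1 to compound 2 (0.83 log units; beyond the scatter), a modest gain on exchanging the group carried on the oxygen of the shared core.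

Compound 4, `COC(C)(C)CCOc1cccc2ccc(N)nc12`, differs from compound 2 in one place: 2-methoxy-2-methylpropyl in place of cyclopentyl on a saturated chain carbon bound to an oxygen on an aromatic ring. This step also reshapes the group on the oxygen, so the step from compound 1 to compound 2 bears on it in showing that this part of the molecule can move the number by a modest amount in either direction. For the measured compounds named here, no measured step, however, exchanges a ring for an open chain or introduces an acceptor into this group, so the direction is not settled by the data. The cautious reading is that compound 4 is expected to lose some binding relative to compound 2, with the step of a 2.5-fold higher number from compound 2 to compound 4 (0.39 log units; beyond the scatter) expected to be modest. Compound 4 is therefore estimated at 130 nM, with a range from 40 nM to 420 nM.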

Compound 4, half-maximal inhibitory concentration: 132 nM
For compound 4 the middle estimate is 1.0-fold (0.01 log units) below the measured one; low and high end bracket the measured number.
By their numbers in this assay, from the lowest: compound 2; then compounds 4 and 3 (each within the scatter of the next); then compound 1.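

In this assay, the change shows a 2.5-fold higher number from compound 2 to compound 4 (0.40 log units; beyond the scatter), on replacing the ring-bearing cyclopentyl with the open-chain 2-methoxy-2-methylpropyl, which brings a hydrogen-bond acceptor that cyclopentyl lacks. Read beside a 6.8-fold lower number from compound 1 to compound 2 (0.83 log units; beyond the scatter), this shows that changes to the group on the oxygen can move the number in either direction, and that here the ring of compound 2 can be given up at a modest cost rather than a large one. Nothing beyond the numbers themselves bears on why this step has its size.

The single step changes the ring, the heavy-atom count and the acceptor count together, so the compounds shown leave open whether the higher number goes with the loss of the ring or with the gain of the methoxy group. An open chain of carbon only, such as 3-methylbutyl, would separate these two changes, while a cyclopentyl ring bearing a methoxy group, or a chain ending in a hydroxyl group or an amine, remains an open case at this place.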